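This account rests on a few compounds, and the source may have more. Where it says the series, first, only, none or still open, it means among the compounds named here.

Measured in an ADME assay on Huh-7 cells (Homo sapiens) for cytotoxicity, with a stated time of 72 h; a lower number here means that less compound is tolerated, a higher number that more compound is tolerated:
Compound 1 `CC(C)CCn1nc(-c2cccs2)c(O)c(C2=NS(=O)(=O)c3cc(NS(=O)(=O)C4CC4)ccc3N2)c1=O`: > 1000 nM
Compound 2 `CCCS(=O)(=O)Nc1ccc2c(c1)S(=O)(=O)N=C(c1c(O)c(-c3cccs3)nn(CCC(C)C)c1=O)N2`: > 1000 nM
Compound 3 `CC(C)CCn1nc(C2CCCC2)c(O)c(C2=NS(=O)(=O)c3cc(NS(C)(=O)=O)ccc3N2)c1=O`: > 1000 nM

Each of these entries is a limit of the assay, not a number. The whole set stands at the limit of > 1000 nM in this assay, at which 3 of the 3 values shown sit, so compound 3 cannot be placed relative to compound 1 or compound 2.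

Compound 4 `CCC(C)(C)c1nn(CCC(C)C)c(=O)c(C2=NS(=O)(=O)c3cc(NS(C)(=O)=O)ccc3N2)c1O` has 1,1-dimethylpropyl in place of cyclopentyl on an aromatic carbon. Going by the values given here, the only measured step is a step that the two limits leave unreadable from compound 1 to compound 2. It lies at a different place, on a sulfonyl sulfur, and gives no size to carry over. Among the compounds with values here, no measured step covers the change from cyclopentyl to 1,1-dimethylpropyl.

The expectation therefore rests on the shared limit and on compound 3 at > 1000 nM, itself a limit. No readable change in this assay is expected, in either direction. The estimated step is a step that the limit leaves unreadable from compound 3 to compound 4. Compound 4 is expected at about 2000 nM. The estimated range runs from 1000 nM to 10000 nM, and the assay will most likely report only a limit again.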

Compound 4, half-maximal cytotoxic concentration: > 1000 nM
Compound 4: no number, only a limit; the forecaster's own chance of this, stated with the estimate: 85%; the middle value does not contradict the limit.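

Compound 4 returns only a limit, as compound 3 does, so no new step between compound 3 and compound 4 can be read in this assay: the limit of > 1000 nM in this assay, at which 4 of the 4 values shown sit.

The compounds shown leave open whether 1,1-dimethylpropyl in place of cyclopentyl changes tolerance at all, and what number any of the four compounds would give.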